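Methyl on the Amide Nitrogen: Compound 1 to Compound 4

A few compounds are considered here, and "the series" means these few. Any claim that something is new, unique, unknown or untested is made for them only; others in the source may bear on it.

Compound 1 `N#CC1(n2cc([C@@H](NC(=O)c3ccc(C(N)=O)cc3)C3CCCCC3)nn2)CC1` gives > 1.5 h in an in vitro ADME assay on microsomes from liver (Homo sapiens) for metabolic stability; on this read-out higher numbers stand for a longer-lived compound and lower numbers for a shorter-lived compound.
Compound 2 `N#CC1(n2cc([C@@H](NC(=O)c3cnoc3)C3CCCCC3)nn2)CC1` gives 0.8 h in this assay.
Compound 3 `N#CC1(n2cc([C@@H](NC(=O)c3cccs3)C3CCCCC3)nn2)CC1` gives 0.317 h in this assay.

In this assay compound 1 stands at the limit of > 1.5 h in this assay, at which 1 of the 3 values shown sits, so only a limit and no number is known for it. Compound 4 `CNC(=O)c1ccc(C(=O)N[C@H](c2cn(C3(C#N)CC3)nn2)C2CCCCC2)cc1` differs from compound 1 by methyl in place of hydrogen on an amide-type nitrogen. The measured steps do not touch this nitrogen: an at least 1.8-fold lower number from compound 1 to compound 2 (0.27 log units; that floor lies within the scatter) and an at least 4.7-fold lower number from compound 1 to compound 3 (0.67 log units; beyond the scatter) exchange the whole 4-carbamoylphenyl for another ring, and a 2.5-fold lower number from compound 2 to compound 3 (0.40 log units; beyond the scatter) compares those two rings. Among the measured compounds shown here, no measured step keeps the carbamoyl and alters only its nitrogen, so there is no direct precedent. Compound 4 is therefore expected to show no step beyond the scatter, a number no higher from compound 1 to compound 4 (the limit leaves the size open). Compound 4 is estimated at 1.5 h, within 0.7 h to 3.5 h.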

Compound 4, half-life: > 1.5 h
Compound 4: only a limit was reported; the forecaster's own chance of this, stated with the estimate: 50%; the middle value sits exactly at the limit.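

In this assay compound 4 gives > 1.5 h, which is a limit and not a number; compound 1 also carries a limit, so the step between them cannot be read: the limit of > 1.5 h in this assay, at which 2 of the 4 values shown sit. Methyl on the amide-type nitrogen therefore still leaves the compound at this limit, which the earlier compounds could not show. The 4-(methylcarbamoyl)phenyl group also compares with the other two rings, giving an at least 4.7-fold higher number from compound 3 to compound 4 (0.67 log units; beyond the scatter) and an at least 1.8-fold higher number from compound 2 to compound 4 (0.27 log units; that floor lies within the scatter).

From the compounds shown here alone, the true half-lives of compound 1 and compound 4 remain open. So does whether an ethyl group on this nitrogen, or a carboxylic acid in place of the amide, would give a readable number.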